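Carbonyl-side substituent changes in one cell assay

A few compounds are considered here, and "the series" means these few. Any claim that something is new, unique, unknown or untested is made for them only; others in the source may bear on it.

compound 1 `COc1cc(NC(C)CCCNC(=O)NCc2ccccc2)c2ncccc2c1`: 35000 nM
compound 2 `CCN(CC)C(=O)NCCCC(C)Nc1cc(OC)cc2cccnc12`: > 100000 nM
compound 3 `COc1cc(NC(C)CCCNC(=O)NC2CCCC2)c2ncccc2c1`: 29000 nM

In an ADME assay on WI-38 cells (Homo sapiens), read by MTT assay, with a stated time of 72 h (a higher number here means a weaker inhibitor, a lower number a stronger inhibitor), compound 3 gives 29000 nM, the lowest of the two numbers; compound 1 gives 35000 nM, with a 1.2-fold lower number from compound 1 to compound 3 (0.08 log units; within the scatter). Compound 2 reaches only a limit of the assay, > 100000 nM (the limit of > 100000 nM in this assay, at which 1 of the 3 values shown sits). Compound 4 `COc1cc(NC(C)CCCNC(=O)n2nnc3ccccc32)c2ncccc2c1` differs from compound 3 by a group of 9 heavy atoms (6 carbon, 3 nitrogen; one five-membered aromatic ring with 3 hetero atoms, one six-membered aromatic ring of carbon only) in place of a group of 6 heavy atoms (5 carbon, 1 nitrogen; one five-membered non-aromatic ring of carbon only), on a carbonyl carbon. Of the measured steps, a 1.2-fold lower number from compound 1 to compound 3 (0.08 log units; within the scatter) shows that exchanging a ring on the amide-type nitrogen leaves the number within the scatter, while an at least 2.8-fold higher number from compound 1 to compound 2 (0.45 log units; beyond the scatter) and an at least 3.4-fold lower number from compound 2 to compound 3 (0.53 log units; beyond the scatter) show that a diethylamino group on the carbonyl carbon weakens. The new group keeps an aromatic ring on that carbon, so no step beyond the scatter is expected, a 1.0-fold higher number from compound 3 to compound 4 (0.01 log units; within the scatter). Compound 4 is estimated at 30000 nM, between 12000 nM and 80000 nM.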

Compound 4, half-maximal inhibitory concentration: > 100000 nM
Compound 4: only a limit was reported; the forecaster's own chance of this, stated with the estimate: 15%; middle value at least 3.3-fold (0.52 log units) away from the limit.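

Compound 4 reaches a limit of the assay, not a number, and the steps still read an at least 3.4-fold higher number from compound 3 to compound 4 (0.53 log units; beyond the scatter) and an at least 2.8-fold higher number from compound 1 to compound 4 (0.45 log units; beyond the scatter). An aromatic ring on the carbonyl carbon therefore does not by itself keep the number near those of compound 1 and compound 3; this change also removes the hydrogen-bond donor of cyclopentylamino, and diethylamino in compound 2 likewise carries no amide hydrogen. The step between compound 2 and compound 4 cannot be read: the limit of > 100000 nM in this assay, at which 2 of the 4 values shown sit.

From the compounds shown here alone, whether the lost amide hydrogen or the fused ring system matters remains open. Phenylamino on the carbonyl carbon would keep that hydrogen with an aromatic ring directly on the nitrogen.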